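The compounds below may be only part of what the source reports. "The series", "measured", "known", "first", "only" and "open" are said of these compounds alone.

Compound 1, `COC/C1=C/C[C@](C)(CCC=C(C)C)/C=C/[C@@H](OC(=O)C=C(C)C)[C@](C)(O)/C=C/C1=O`: 3950 nM
Compound 2, `CC(C)=CCC[C@]1(C)/C=C/[C@@H](OC(=O)C=C(C)C)[C@](C)(O)/C=C/C(=O)/C(Cn2cc(CO)nn2)=C\C1`: 3470 nM
Compound 3, `CO/N=C/C1=C/C[C@](C)(CCC=C(C)C)/C=C/[C@@H](OC(=O)C=C(C)C)[C@](C)(O)/C=C/C1=O`: 3470 nM

These three numbers all come from a functional assay on A549 cells (Homo sapiens) for antiproliferative activity, read by MTT assay, with a stated time of 48 h; a higher number here means a weaker inhibitor, a lower number a stronger inhibitor. Compound 1 carries the nominally highest number of the three, but the step of a 1.1-fold lower number from compound 1 to compound 2 (0.06 log units; within the scatter) and the step of a 1.1-fold lower number from compound 1 to compound 3 (0.06 log units; within the scatter) both fall within the scatter, so the three compounds cannot be told apart on these data. All three share one core and differ only in the group attached to a double-bonded ring carbon of that core.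

Compound 4, `CC(C)=CCC[C@]1(C)/C=C/[C@@H](OC(=O)C=C(C)C)[C@](C)(O)/C=C/C(=O)/C(C(=O)N(C(C)C)C(C)C)=C\C1`, is not yet measured. It differs from compound 1 in one place: diisopropylcarbamoyl in place of methoxymethyl on a double-bonded ring carbon. The same position is the one that was varied in the steps from compound 1 to compound 2 and from compound 1 to compound 3, and in both cases swapping the group there left the number unchanged within the scatter. Those two steps are therefore the ones that bear on compound 4, and they suggest that this position tolerates quite different groups without moving the readout. The expectation for compound 4 is accordingly a step of no real size in this assay, written as a 1.1-fold lower number from compound 1 to compound 4 (0.05 log units; within the scatter). The estimated value for compound 4 is 3500 nM, expected to lie between 1500 nM and 8000 nM.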

Compound 4, half-maximal inhibitory concentration: 13500 nM
For compound 4 the middle estimate is 3.9-fold (0.59 log units) below the measured one; measured number outside the range, above it.
By their numbers in this assay, from the lowest: compounds 2, 3 and 1 (each within the scatter of the next); then compound 4.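

In this assay, among these compounds, the earlier compounds suggested that this double-bonded ring carbon accepts very different groups without any readable change, and compound 4 sets a limit on that picture. Diisopropylcarbamoyl in place of methoxymethyl gives a 3.4-fold higher number from compound 1 to compound 4 (0.53 log units; beyond the scatter), the first step at this place to stand beyond the scatter, though it is only modest in size. The comparisons with the other two compounds agree, with a 3.9-fold higher number from compound 3 to compound 4 (0.59 log units; beyond the scatter) and a 3.9-fold higher number from compound 2 to compound 4 (0.59 log units; beyond the scatter), so compound 4 is the weakest of the four, while compounds 1, 2 and 3 remain within the scatter of one another.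

No measurement at hand says why the number rises with this group. The compounds shown leave open whether the weakening goes with the amide link itself or with the two isopropyl groups on its nitrogen, and a dimethylcarbamoyl group, an unsubstituted carboxamide or a carboxylic acid at the same place would help separate these possibilities. They also leave open whether any group here can give a clearly lower number than compounds 1, 2 and 3.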